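Working notes on an antiproliferative series, compound 3 pending

The source may hold more compounds than are shown below. What is called first, only, known or untested is meant among the compounds shown, and "the series" means these compounds.

Measured in a functional assay on T84 cells (Homo sapiens) for antiproliferative activity, read by MTT assay, with a stated time of 72 h; on this read-out higher numbers stand for weaker inhibition and lower numbers for stronger inhibition:
compound 1 `COc1cc(/C=C2\CCC/C(=C\c3ccccc3F)C2=O)cc(OC)c1OC`: compound 1 gives 2200 nM
compound 2 `COc1cc(/C=C2\CCC/C(=C\c3cccc(O)c3)C2=O)cc(OC)c1OC`: compound 2 gives 6500 nM

For the measured compounds named here, compound 2 stands highest of the two numbers in this assay; the nearest is compound 1, and the only step recorded, a 3.0-fold higher number from compound 1 to compound 2 (0.47 log units; beyond the scatter), is modest and beyond the scatter. Compound 3 `COc1cccc(/C=C2\CCC/C(=C\c3cc(OC)c(OC)c(OC)c3)C2=O)c1OC` differs from compound 2 by 2,3-dimethoxyphenyl in place of 3-hydroxyphenyl on a double-bonded chain carbon bound to a double-bonded ring carbon. Going by the values given here, no step bears directly on this exchange; the single step touches the same place but a different group, so it guides only loosely. A step to a lower number is expected in this assay, likely near the scatter: a 2.2-fold lower number from compound 2 to compound 3 (0.34 log units; beyond the scatter). Compound 3 is estimated at 3000 nM, range 1000 nM to 9000 nM.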

Compound 3, half-maximal inhibitory concentration: 3900 nM
Compound 3: the middle estimate sits 1.3-fold (0.11 log units) below what was measured, and the stated range covers the measured number.
By their numbers in this assay, from the lowest: compounds 1, 3 and 2 (each within the scatter of the next, the first and the last beyond it).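

In this assay, 2,3-dimethoxyphenyl at this place gives a 1.7-fold lower number from compound 2 to compound 3 (0.22 log units; within the scatter) and a 1.8-fold higher number from compound 1 to compound 3 (0.25 log units; within the scatter), so compound 3 cannot be told apart from either neighbour, although compound 1 and compound 2 differ beyond the scatter. Replacing 3-hydroxyphenyl, with its hydrogen-bond donor, by a larger group with no donor therefore leaves the number within the scatter. Nothing on hand explains this result.

On these data alone, whether an amine or a carboxylic acid at this place would shift the number beyond the scatter stays open. Also open, as far as these compounds go, is whether a single methoxy group would read like the 2,3-dimethoxyphenyl group.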